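Trading a Cyclobutyl Amide for a Bicyclic One

The compounds below may be only part of what the source reports. "The series", "measured", "known", "first", "only" and "open" are said of these compounds alone.

Of the compounds shown here, three sharing one core have been measured in an assay on HEK293 cells for positive allosteric modulation of metabotropic glutamate receptor 5 (Homo sapiens), read by FLIPR; a higher number here means that more compound is needed for the effect, a lower number that less compound is needed. Compound 1, `O=C([C@H]1CC2CCC1C2)N1CC(c2nc(-c3cccc(F)c3)no2)C1`, gives 72 nM. Compound 3, `Cc1ccc(C(=O)N2CC(c3nc(-c4cccc(F)c4)no3)C2)cc1`, gives 6800 nM. Compound 2, `O=C(C1CCC1)N1CC(c2nc(-c3cccc(Cl)c3)no2)C1`, reaches only a limit of this assay, > 10000 nM, so no number is known for it and it stands at the weak end of what is shown.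

The step considered here leads from compound 2 to compound 4, `O=C([C@H]1CC2CCC1C2)N1CC(c2nc(-c3cccc(Cl)c3)no2)C1`. The change is a group of 7 heavy atoms (7 carbon; 2 five-membered non-aromatic rings of carbon only) in place of a group of 4 heavy atoms (4 carbon; one four-membered non-aromatic ring of carbon only), on a carbonyl carbon. Compound 4 thus carries the same bicyclic amide as compound 1, paired with the aromatic part of compound 2.

Within the data shown here, one measured step bears on this: a 94-fold higher number from compound 1 to compound 3 (1.98 log units; beyond the scatter). There the bicyclic group on the carbonyl carbon was replaced by an aromatic ring and the number rose sharply, showing that this bicyclic amide is linked to much lower numbers than the other amides measured. Compound 2, with its cyclobutyl amide, sits at the limit of > 10000 nM in this assay, at which 1 of the 3 values shown sits, which fits the same picture.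

Compound 4 is therefore expected to move strongly toward lower numbers, and the estimate is 100 nM, with a range from 30 nM to 400 nM. That estimate means an expected step of an at least 100-fold lower number from compound 2 to compound 4 (2.00 log units; beyond the scatter), well beyond the scatter.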

Compound 4, half-maximal effective concentration: 74 nM
Beside the measured number, compound 4's estimate is 1.4-fold (0.13 log units) above it; the range from low to high includes it.
By their numbers in this assay, from the lowest: compounds 1 and 4 (each within the scatter of the next); then compound 3. At a limit, above all of these: compound 2.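

With the chloro-bearing aromatic part held fixed, putting the bicyclic group in place of cyclobutyl on the carbonyl carbon gives an at least 130-fold lower number from compound 2 to compound 4 (2.13 log units; beyond the scatter), and the true size of this step is unknown, as compound 2 gives only a limit of this assay: the limit of > 10000 nM in this assay, at which 1 of the 4 values shown sits.

The earlier step compared the bicyclic amide only with an aromatic amide, and only with the fluoro-bearing aromatic part, whereas this pair sets it against a small saturated ring amide with the chloro-bearing part, so the large gain in these compounds appears with both aromatic parts. Chloro in place of fluoro on an aromatic carbon gives a 1.0-fold higher number from compound 1 to compound 4 (0.01 log units; within the scatter), so with the bicyclic amide in place, the two halogens cannot be told apart here.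

From the compounds shown here alone, it stays open whether a cyclohexyl group or an open pentyl chain on the same carbonyl carbon would also give numbers this low, and how the mirror-image form of the bicyclic group would compare. Also open, going by these compounds, is whether a methoxy group or a nitrile could take the place of chloro or fluoro on the aromatic ring without raising the number.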